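Cytotoxicity notes: thiophene to pyridine on the ether arm

The compounds below may be only part of what the source reports. "The series", "measured", "known", "first", "only" and "open" are said of these compounds alone.

Three compounds of the series have readings in an ADME assay on MT2 cells (Homo sapiens) for cytotoxicity, read by MTT assay; on this read-out higher numbers stand for lower toxicity in this test and lower numbers for higher toxicity in this test. Compound 1 `CSCc1ccc(Nc2ncc(Cc3c(F)cccc3F)o2)cc1` gives a limit, > 100000 nM, in this assay. Compound 2 `Fc1cccc(F)c1Cc1cnc(Nc2ccc(Oc3cccnc3)c(Cl)c2)o1` gives 16000 nM in this assay. Compound 3 `Clc1cccc(Cl)c1Cc1nnc(Nc2ccc(COCc3ccsc3)cc2)o1` gives only a limit, > 100000 nM, in this assay. Going by the values given here, compound 3 thus stands at the limit of > 100000 nM in this assay, at which 2 of the 3 values shown sit, together with compound 1, while compound 2 is the one reading that is a number rather than a limit.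

Among the compounds with values here, no step between measured compounds exists here: compounds 1, 2 and 3 differ from one another in more than one place, so only their values can be set side by side.

Compound 4 `Clc1cccc(Cl)c1Cc1nnc(Nc2ccc(COCc3ccncc3)cc2)o1` has not been measured. It differs from compound 3 in one place: pyridin-4-yl in place of thiophen-3-yl on a saturated chain carbon bound to an oxygen on a saturated carbon. One aromatic ring is exchanged for another at the end of the ether arm.

Compound 3 sits at the limit, and no shown step says the exchange should move it, so the step from compound 3 to compound 4 is expected to be a number no higher from compound 3 to compound 4 (the limit leaves the size open), none beyond the scatter. Compound 4 is therefore expected to give about 100000 nM in this assay, in a range from 30000 nM to 300000 nM, most likely again as a limit.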

Compound 4, half-maximal cytotoxic concentration: 81000 nM
The estimate for compound 4 lay 1.2-fold (0.09 log units) above the measured number; measured number inside the range.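

In this assay, pyridin-4-yl in place of thiophen-3-yl on a saturated chain carbon bound to an oxygen on a saturated carbon gives an at least 1.2-fold lower number from compound 3 to compound 4 (0.09 log units; that floor lies within the scatter). This is the first step shown at this position, and it gives this ether arm a reading that is a number in compound 4, not a limit. The true size of the step cannot be read, because the reading of compound 3 is a limit and not a number: the limit of > 100000 nM in this assay, at which 2 of the 4 values shown sit.

On these data alone, whether a plain phenyl ring or a saturated amine such as morpholin-4-yl at the same place would give a number or a limit remains open. As far as these compounds go, it is also open whether the same exchange would behave alike on the core of compound 1.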